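This account rests on a few compounds, and the source may have more. Where it says the series, first, only, none or still open, it means among the compounds named here.

In an ADME assay (liver) for metabolic stability, with Liver microsome (Homo sapiens) as the target, using microsomes and NADPH, with a stated time of 30 min, tested at 1 uM (a higher number here means faster removal of the compound, a lower number slower removal), compound 1 `Cn1cc(-c2cc(C(O)(C(F)(F)F)C(F)(F)F)cnc2N2CCN(S(=O)(=O)c3ccc(N)nc3)CC2)cn1` gives 19 mL.min-1.g-1 and compound 2 `Nc1ccc(S(=O)(=O)N2CCN(c3ncc(C(O)(C(F)(F)F)C(F)(F)F)cc3-c3cccnc3)CC2)cn1` gives 17 mL.min-1.g-1 so the two stand level within the scatter. Compound 3 `COc1ccc(-c2cc(C(O)(C(F)(F)F)C(F)(F)F)cnc2N2CCN(S(=O)(=O)c3ccc(N)nc3)CC2)cn1` differs from compound 2 by methoxy in place of hydrogen on an aromatic carbon in one place: methoxy in place of hydrogen on an aromatic carbon. Going by the values given here, the only measured step of a 1.1-fold lower number from compound 1 to compound 2 (0.05 log units; within the scatter) swaps one aromatic ring for another and stays within the scatter, but no measured compound carries a methoxy group, so it offers only indirect guidance. The estimated step of a 1.4-fold higher number from compound 2 to compound 3 (0.13 log units; within the scatter) is expected to be small, upward if anything, and may not clear the scatter. Compound 3 is expected at 23 mL.min-1.g-1 with 12 mL.min-1.g-1 to 45 mL.min-1.g-1 as the estimated range.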

Compound 3, intrinsic clearance in microsomes: 25 mL.min-1.g-1
The estimate for compound 3 lay 1.1-fold (0.04 log units) below the measured number, and the stated range covers the measured number.
By their numbers in this assay, from the lowest: compounds 2, 1 and 3 (each within the scatter of the next).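

In this assay, placing methoxy on the pyridin-3-yl ring, next to the ring nitrogen, gives a 1.5-fold higher number from compound 2 to compound 3 (0.17 log units; within the scatter) and so does not clear the scatter at this position. Replacing the 1-methyl-1H-pyrazol-4-yl group with 6-methoxypyridin-3-yl gives a 1.3-fold higher number from compound 1 to compound 3 (0.12 log units; within the scatter) and also stays within it. No supporting information bears on these results. Going by these compounds, whether an amine or a longer chain such as ethoxy at the same place would move the number beyond the scatter remains open.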